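From Methyl to Isopropoxy on Compound 3

The source may hold more compounds than are shown below. What is called first, only, known or untested is meant among the compounds shown, and "the series" means these compounds.

Of the compounds shown here, three have been measured so far in a functional assay on A549 cells (Homo sapiens) for antiproliferative activity, read by sulforhodamine B assay, with a stated time of 72 h; a lower number here means a stronger inhibitor, a higher number a weaker inhibitor. Compound 1 (`CCOc1cc2occ(-c3csc4ccccc34)c(=O)c2c(OCC)c1OC`) gives 2600 nM, compound 2 (`COc1cc2occ(-c3csc4ccccc34)c(=O)c2c(OC)c1OC`) gives 640 nM, and compound 3 (`Cc1ccc(O)c(C(=O)/C=C/c2csc3ccccc23)c1`) gives 4800 nM. Compound 3 therefore stands within the scatter of compound 1, while the number for compound 2 lies below that of compound 3 by a margin beyond the scatter.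

For the measured compounds named here, the next compound, compound 4 (`CC(C)Oc1ccc(O)c(C(=O)/C=C/c2csc3ccccc23)c1`), has no measurement yet. It keeps the rest of compound 3 and carries isopropoxy in place of methyl on an aromatic carbon. The change sits on a six-membered aromatic ring of carbon only, meta to a large group and para to a hydroxy group.

Going by the values given here, no two measured compounds differ in one place only, so the data offer no direct measure of what such a change does. On these data alone, with nothing to set against it, no step beyond the scatter is expected in this assay, and the direction remains open. The estimated step of a 1.3-fold lower number from compound 3 to compound 4 (0.10 log units; within the scatter) is therefore small and rests only on the value of compound 3 at 4800 nM. For compound 4 the estimate is 3800 nM, with an expected range from 1300 nM to 11000 nM.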

Compound 4, half-maximal inhibitory concentration: 6400 nM
Compound 4: the middle estimate sits 1.7-fold (0.23 log units) below what was measured; the measured number falls inside the stated range.
By their numbers in this assay, from the lowest: compound 2; then compounds 1, 3 and 4 (each within the scatter of the next, the first and the last beyond it).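

In this assay, for the compounds shown here, placing isopropoxy in place of methyl on this aromatic carbon, meta to a large group and para to a hydroxy group, gives a 1.3-fold higher number from compound 3 to compound 4 (0.12 log units; within the scatter) and thus provides the one step that can be read at a single place. Going by these compounds alone, it shows that this position accepts isopropoxy, which brings an oxygen and a branched chain, in place of methyl with no change beyond the scatter, something the earlier compounds, which offered no such pair, could not show. Nothing shown bears on the reason for this result.

The compounds shown leave open whether this tolerance extends to other groups at the same carbon, such as a free hydroxy, an amine, a carboxylic acid or a longer unbranched alkoxy chain such as butoxy, since one exchange marks out only a single point. They also leave open whether the same exchange would behave alike at other places on this ring or on the different core of compound 1 and compound 2.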